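Iodophenyl in place of ethylphenyl on the shared core

The compounds below may be only part of what the source reports. "The series", "measured", "known", "first", "only" and "open" are said of these compounds alone.

Measured compounds:
Compound 1 `COC(=O)C1=C(C)N=C(C)/C(=C(\O)OC)C1c1cc([N+](=O)[O-])ccc1Cl`: 30.2 nM
Compound 2 `CCc1ccccc1C1C(C(=O)OC)=C(C)N=C(C)/C1=C(\O)OC`: 6.46 nM

The read-out is a functional assay (muscle tissue) with Cavia porcellus as the target; on this read-out higher numbers stand for an effect only at larger amounts of compound and lower numbers for an effect already at smaller amounts. Among the two measured compounds, compound 2 stands at the lowest number, and compound 1 sits at a higher one; the gap between them is beyond the scatter. Compound 3 `COC(=O)C1=C(C)N=C(C)/C(=C(\O)OC)C1c1cccc(I)c1` has not yet been measured in this assay. It differs from compound 2 in one place: 3-iodophenyl in place of 2-ethylphenyl on a saturated ring carbon. Within the data shown here, no step between measured compounds covers this particular change, so the expectation rests on the position of compound 2 alone. A modest move to higher numbers, of a size that may stay within the scatter, is expected from compound 2 to compound 3, at a 1.5-fold higher number from compound 2 to compound 3 (0.19 log units; within the scatter). Compound 3 is therefore estimated at 10 nM, with a range from 2.5 nM to 40 nM.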

Compound 3, half-maximal effective concentration: 41.7 nM
Beside the measured number, compound 3's estimate is 4.2-fold (0.62 log units) below it; measured number above the stated range.
By their numbers in this assay, from the lowest: compound 2; then compounds 1 and 3 (each within the scatter of the next).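

Read in this assay, putting 3-iodophenyl in place of 2-ethylphenyl on the saturated ring carbon gives a 6.5-fold higher number from compound 2 to compound 3 (0.81 log units; beyond the scatter). Among these compounds, this is the first step that can be read at this position, and it shows that the number here responds to a swap between these two substituted phenyl groups, even though both carry no hydrogen-bond donors or acceptors and no net charge. Nothing measured accounts for the size of this step.

Because the substituent and its place on the phenyl ring change together, the compounds shown cannot separate the contribution of each. As far as these compounds go, how a phenyl ring bearing an amine or a carboxylic acid would read at this position also remains open.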